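The source may hold more compounds than are shown below. What is called first, only, known or untested is meant among the compounds shown, and "the series" means these compounds.

Compound 2 `OC(c1cnc2scc(-c3ccc(Br)cc3)n12)C1CCCCC1` gives 1280 nM in an assay on cells for inhibition of Indoleamine 2,3-dioxygenase 1 (Homo sapiens); on this read-out lower numbers stand for stronger inhibition and higher numbers for weaker inhibition; compound 1 `OC(c1ccccc1)c1cnc2scc(-c3ccc(Br)cc3)n12` gives 1090 nM, and the two lie within the scatter of each other, as a 1.2-fold higher number from compound 1 to compound 2 (0.07 log units; within the scatter) shows. Compound 3 `OC(c1cnc2scc(C#CC3CC3)n12)C1CCCCC1` alters a different place: 2-cyclopropylethynyl in place of 4-bromophenyl on an aromatic carbon. Among the compounds with values here, no measured step touches that aromatic carbon; the single measured step concerns only the saturated chain carbon and says nothing direct about the aryl replacement. For compound 3 the step expected in this assay is a 2.0-fold higher number from compound 2 to compound 3 (0.29 log units; within the scatter), toward a weaker number, with wide uncertainty. Compound 3 is therefore estimated at 2500 nM, within 600 nM to 10000 nM.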

Compound 3, half-maximal inhibitory concentration: 7150 nM
For compound 3 the middle estimate is 2.9-fold (0.46 log units) below the measured one; low and high end bracket the measured number.
By their numbers in this assay, from the lowest: compounds 1 and 2 (each within the scatter of the next); then compound 3.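

The aromatic carbon next to the ring nitrogen is sensitive to change, unlike the saturated chain carbon in the earlier step: in this assay, 2-cyclopropylethynyl in place of 4-bromophenyl gives a clear loss (a 5.6-fold higher number from compound 2 to compound 3 (0.75 log units; beyond the scatter)). This single swap changes the ring, the bromine and the triple bond together, so their contributions cannot be separated. No available data explain the step.

Open, on these data alone, is whether phenyl without bromine, or a 4-aminophenyl, would hold the number of compound 2. Also open, as far as these compounds go, is how 2-cyclopropylethynyl behaves with phenyl in place of cyclohexyl on the chain carbon.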